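This account rests on a few compounds, and the source may have more. Where it says the series, first, only, none or still open, it means among the compounds named here.

Measured in a functional assay on U-373MG ATCC cells (Homo sapiens) for inhibition, read by MTT assay, with a stated time of 72 h; a lower number here means a stronger inhibitor, a higher number a weaker inhibitor:
- compound 1 `CC1(C)CC(NC(=S)NCc2ccccc2)c2cc(F)ccc2O1`: 27000 nM
- compound 2 `CC1(C)CC(NC(=S)Nc2cccc(C#N)c2)c2cc(F)ccc2O1`: 30000 nM

For the measured compounds named here, compound 2 cannot be separated from the only other measured compound: a 1.1-fold higher number from compound 1 to compound 2 (0.05 log units; within the scatter), which lies within the scatter. Going by the values given here, both numbers sit close together, and the series so far offers no spread in this assay.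

The next compound is compound 3 `CC1(C)CC(NC(=S)Nc2cccc(C#N)c2)c2cc(Cl)ccc2O1`, which keeps the 3-cyanophenyl group of compound 2 and changes the halogen: chloro in place of fluoro on an aromatic carbon. The exchange is chloro in place of fluoro on an aromatic carbon of the shared core.

Among the compounds with values here, the one measured step concerns another place, 3-cyanophenyl in place of benzyl on an amide-type nitrogen, and it leaves the fluoro untouched. It bears on the new change only indirectly, as a sign that one change to this series has so far moved little. No measurement covers chloro in place of fluoro, so the data support no firm direction.

The estimated step is a 1.2-fold lower number from compound 2 to compound 3 (0.08 log units; within the scatter), and none beyond the scatter is expected. The expectation starts from compound 2 at 30000 nM.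

Compound 3 is expected at 25000 nM, with an estimated range of 11000 nM to 55000 nM.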

Compound 3, half-maximal inhibitory concentration: 7000 nM
Estimate against measurement, compound 3: 3.6-fold (0.55 log units) above; measured number outside the range, below it.
By their numbers in this assay, from the lowest: compound 3; then compounds 1 and 2 (each within the scatter of the next).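

In this assay, the aromatic carbon carrying the halogen on the shared core responds to substitution: chloro in place of fluoro gives a 4.3-fold lower number from compound 2 to compound 3 (0.63 log units; beyond the scatter). The change on the amide-type nitrogen, by contrast, gave a 1.1-fold higher number from compound 1 to compound 2 (0.05 log units; within the scatter), so of the two places varied so far, only this aromatic carbon has moved the number beyond the scatter. No data at hand account for the difference between the two halogens.

Chloro appears here only with the 3-cyanophenyl group, so it remains open whether the same exchange holds with the benzyl group of compound 1. Also open, from the compounds shown here alone, is how this aromatic carbon responds to groups such as bromo, methyl or methoxy, and so whether the step from fluoro to chloro is part of a wider trend or is specific to this one pair of halogens.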